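The source may hold more compounds than are shown below. What is called first, only, known or untested is meant among the compounds shown, and "the series" means these compounds.

Working notes on the series. The core of compound 1 `O=C(O)c1cn(C2CC2)c2nc(N3CCN(C(c4ccccc4)c4ccc(Cl)cc4)CC3)c([N+](=O)[O-])cc2c1=O` carries a cyclopropyl on an aromatic nitrogen; in an ADME assay on Vero cells (Chlorocebus sabaeus) for cytotoxicity, read by MTT assay, with a stated time of 72 h (on this read-out higher numbers stand for weaker inhibition and lower numbers for stronger inhibition), compound 1 gives 112000 nM. Compound 3 `O=C(O)c1cn(-c2ccc(F)cc2)c2nc(N3CCN(C(c4ccccc4)c4ccc(Cl)cc4)CC3)c([N+](=O)[O-])cc2c1=O` is the same core with the change (4-fluorophenyl in place of cyclopropyl on an aromatic nitrogen), and in this assay compound 3 gives 102000 nM. Among the measured compounds shown here, the step of a 1.1-fold lower number from compound 1 to compound 3 (0.04 log units; within the scatter) is the only measured instance of this change, and it sits within the scatter.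

Compound 2 `CC1CN(c2nc3c(cc2[N+](=O)[O-])c(=O)c(C(=O)O)cn3C2CC2)CC(C)O1` has a different core; how the two cores differ is not broken down here. In this assay compound 2 gives only a limit of the assay, > 160000 nM. One of the three values shown sits at this limit, as noted in the limit of > 160000 nM in this assay, at which 1 of the 3 values shown sits.

Compound 4 `CC1CN(c2nc3c(cc2[N+](=O)[O-])c(=O)c(C(=O)O)cn3-c2ccc(F)cc2)CC(C)O1` is not yet measured and carries the change (4-fluorophenyl in place of cyclopropyl on an aromatic nitrogen), the same change as between compound 1 and compound 3. The expected step that the limit leaves unreadable from compound 2 to compound 4 is estimated to be small, resting on compound 1 and compound 3 with the step of a 1.1-fold lower number from compound 1 to compound 3 (0.04 log units; within the scatter). Compound 4 is therefore expected to give about 180000 nM in this assay, with a range from 100000 nM to 320000 nM, and most likely only a limit.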

Compound 4, half-maximal inhibitory concentration: 141000 nM
The estimate for compound 4 lay 1.3-fold (0.11 log units) above the measured number; low and high end bracket the measured number.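

In this assay, 4-fluorophenyl in place of cyclopropyl on an aromatic nitrogen now appears on a second core, as an at least 1.1-fold lower number from compound 2 to compound 4 (0.05 log units; that floor lies within the scatter). Set beside the instance on the core of compound 1, the two steps read as follows: the same change on two cores in this assay, a 1.1-fold lower number (0.04 log units; within the scatter) from compound 1 to compound 3 and an at least 1.1-fold lower number (0.05 log units; that floor lies within the scatter) from compound 2 to compound 4; the limit leaves it open whether they differ. Compound 2 stands at a limit of the assay, > 160000 nM, so this pair fixes only a floor for the step; it does not show that the change carries from one core to the other with the same size, nor that it does not.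

The compounds shown leave open what an ethyl group or another short carbon chain, or a phenyl bearing an amine, would give in place of cyclopropyl on that aromatic nitrogen in this assay. Also open, from the compounds shown here alone, is whether a core with an amide in place of the carboxy group would respond to the same change as these two cores do.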